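Fluoro for phenyl in the cytotoxicity series

This account rests on a few compounds, and the source may have more. Where it says the series, first, only, none or still open, it means among the compounds named here.

Measured so far:
compound 1 `CCOC(=O)c1c(-c2cc(F)cc(OC)c2)[nH]c2cc(OC)ccc2c1=O` — > 21500 nM
compound 2 `CCOC(=O)c1c(-c2cccc(-c3ccccc3)c2)[nH]c2cc(OC)ccc2c1=O` — > 21500 nM
compound 3 `CCCOc1cccc(-c2[nH]c3cc(OC)ccc3c(=O)c2C(=O)OCC)c1` — > 21500 nM

In an ADME assay on BJ cells (Homo sapiens) for cytotoxicity, read by luminescence, with a stated time of 72 h (on this read-out higher numbers stand for an effect only at larger amounts of compound and lower numbers for an effect already at smaller amounts), compound 2 gives only a limit, > 21500 nM. Compound 1 also returns a limit in this assay. Compound 3 likewise returns a limit. Among the measured compounds shown here, the single measured step, a step that the two limits leave unreadable from compound 2 to compound 3, is therefore unreadable. Compound 4 `CCOC(=O)c1c(-c2cccc(F)c2)[nH]c2cc(OC)ccc2c1=O` differs from compound 2 by fluoro in place of phenyl on an aromatic carbon. For the measured compounds named here, no measured step bears on this change, and with the limit of > 21500 nM in this assay, at which 3 of the 3 values shown sit, no number has yet been read for any member of the series, so no step of any size is visible. For compound 4 the expected step is a step that the limit leaves unreadable from compound 2 to compound 4, that is none beyond the scatter. Compound 4 is expected at 30000 nM, between 15000 nM and 80000 nM, most probably again as a limit.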

Compound 4, half-maximal effective concentration: > 21500 nM
Compound 4 ended at the assay's limit; the forecaster's own chance of this, stated with the estimate: 85%; the middle value does not contradict the limit.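

In this assay no new step can be read between compound 4 and compound 1, compound 2 or compound 3, since all four values are limits: the limit of > 21500 nM in this assay, at which 4 of the 4 values shown sit. The compounds shown leave open at what concentration any of them reaches a half-maximal effect.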